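This account rests on a few compounds, and the source may have more. Where it says the series, first, only, none or still open, it means among the compounds named here.

Compound 1, with structure `COc1cc2c(Oc3c(F)cc(NC(=O)NN4C(=O)CSC4c4c(F)cccc4F)cc3F)ccnc2cc1OCCCN1CCCC1`, and compound 2, with structure `COc1cc2c(Oc3c(F)cc(NC(=O)NN4C(=O)CSC4c4c(F)cccc4F)cc3F)ccnc2cc1OCCCN1CCN(C)CC1`, share one core and differ only in the amine at the end of the side chain. In a functional assay on MDA-MB-231 cells (Homo sapiens) for antiproliferative activity, read by MTT assay, with a stated time of 72 h (on this read-out higher numbers stand for weaker inhibition and lower numbers for stronger inhibition), compound 1 gives 8350 nM, and compound 2 gives 4360 nM. Among the compounds with values here, the step of a 1.9-fold lower number from compound 1 to compound 2 (0.28 log units; within the scatter) is the only comparison available, and it sits within the scatter, so the two compounds cannot be ranked; compound 2 merely shows the lower of the two numbers.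

Compound 3, with structure `COc1cc2c(Oc3c(F)cc(NC(=O)NN4C(=O)CSC4c4c(F)cccc4F)cc3F)ccnc2cc1OCCCN1CCC(N2CCCCC2)CC1`, changes the same terminal amine again: 4-(piperidin-1-yl)piperidin-1-yl in place of 4-methylpiperazin-1-yl on a saturated chain carbon, three bonds along the chain from an oxygen on an aromatic ring. Within the data shown here, the one measured step at this position, the exchange of the amines that separates compound 1 from compound 2, produced no shift beyond the scatter, and nothing else in the data bears on this change. Compound 3 is therefore expected to stay close to compound 2, with a step of a 1.1-fold lower number from compound 2 to compound 3 (0.04 log units; within the scatter) in this assay. The estimate for compound 3 is 4000 nM, with a range from 1500 nM to 12000 nM.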

Compound 3, half-maximal inhibitory concentration: 5380 nM
Estimate against measurement, compound 3: 1.3-fold (0.13 log units) below; the range from low to high includes it.
By their numbers in this assay, from the lowest: compounds 2, 3 and 1 (each within the scatter of the next).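

Across pyrrolidin-1-yl, 4-methylpiperazin-1-yl and 4-(piperidin-1-yl)piperidin-1-yl, every printed step at this saturated chain carbon in this assay now lies within the scatter. Placing 12 heavy atoms in two six-membered rings where there were 7 in one gives only a 1.2-fold higher number from compound 2 to compound 3 (0.09 log units; within the scatter) and the exchange with pyrrolidin-1-yl gives a 1.6-fold lower number from compound 1 to compound 3 (0.19 log units; within the scatter) so this larger amine separates from neither of the earlier two. Nothing available explains these numbers.

The compounds shown all end in saturated ring amines, so it remains open whether a morpholine, an open-chain dimethylamino group or a carboxylic acid at this place would move the number beyond the scatter. As far as these compounds go, whether a longer or shorter chain between the oxygen and the amine would do so also remains open.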